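This account rests on a few compounds, and the source may have more. Where it says the series, first, only, none or still open, it means among the compounds named here.

Of the compounds shown here, three sharing one core have been measured in a functional assay on MCF7 cells (Homo sapiens) for cytotoxicity, read by MTT assay, with a stated time of 72 h; a higher number here means a weaker inhibitor, a lower number a stronger inhibitor. Compound 1 `Nc1ccc(Nc2c(C(=O)NCc3ccc(F)cc3)nc(Br)c3cccnc23)cc1` gives 4000 nM in this assay. Compound 2 `CNCCCNc1c(C(=O)NCc2ccc(F)cc2)nc(Br)c2cccnc12` gives > 10000 nM, which is a limit of the assay and not a number. Compound 3 `O=C(NCCCNc1c(C(=O)NCc2ccc(F)cc2)nc(Br)c2cccnc12)c1ccccc1` gives 2000 nM, the lowest of the two numbers; compound 1 lies within the usual scatter of it, so no order can be drawn between those two. Compound 4 `NCCCNc1c(C(=O)NCc2ccc(F)cc2)nc(Br)c2cccnc12` has not yet been measured in this assay. It differs from compound 3 by hydrogen in place of benzoyl on an amine nitrogen, the benzoyl on the amine nitrogen giving way to hydrogen. The measured step bearing most directly on this change is an at least 5.0-fold lower number from compound 2 to compound 3 (0.69 log units; beyond the scatter), where benzoyl entered in place of methyl on an amine nitrogen; compound 4 runs that change backwards, to a bare hydrogen. The step of an at least 2.5-fold higher number from compound 1 to compound 2 (0.39 log units; beyond the scatter) also ended at the limit. Compound 4 is therefore expected to give a higher number, with a 5.0-fold higher number from compound 3 to compound 4 (0.70 log units; beyond the scatter). Compound 4 is estimated at 10000 nM, expected to fall between 4000 nM and 25000 nM, and it may sit at the limit of > 10000 nM in this assay, at which 1 of the 3 values shown sits.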

Compound 4, half-maximal inhibitory concentration: 6000 nM
The estimate for compound 4 lay 1.7-fold (0.22 log units) above the measured number, within the range that was stated.
By their numbers in this assay, from the lowest: compounds 3, 1 and 4 (each within the scatter of the next, the first and the last beyond it). At a limit, above all of these: compound 2.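

In this assay, among these compounds, hydrogen in place of benzoyl on the amine nitrogen gives a 3.0-fold higher number from compound 3 to compound 4 (0.48 log units; beyond the scatter), the first change at this position with a number at both ends and a modest one. 3-Aminopropyl in place of 4-aminophenyl on a nitrogen on an aromatic ring gives a 1.5-fold higher number from compound 1 to compound 4 (0.18 log units; within the scatter), so no order can be drawn between the two. Compound 2 stands at a limit of the assay and not a number: the limit of > 10000 nM in this assay, at which 1 of the 4 values shown sits. Hydrogen in place of methyl on the amine nitrogen gives an at least 1.6-fold lower number from compound 2 to compound 4 (0.22 log units; that floor lies within the scatter), so this step cannot be read as a difference.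

Going by these compounds, only hydrogen, methyl and benzoyl stand on this amine nitrogen, and it stays open whether an acetyl group, with the carbonyl but without the ring, would match compound 3. On these data alone, how a longer chain would read against the 3-aminopropyl chain also stays open.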